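The source may report more compounds than this note shows. Statements on the series, on what has been measured and on what is new or still open speak of the compounds shown alone.

Compound 2 `COc1cccc(Oc2ccc3c(NCCCNCc4cccc(OC)c4O)ccnc3c2)c1` gives 317 10^-6 cm/s in an ADME assay for permeability, using PAMPA, with a stated time of 30 min, at pH 7.4 (a lower number here means that the compound crosses the layer more slowly, a higher number that the compound crosses the layer faster), level with compound 1 `COc1cccc(Oc2ccc3c(NCCCNCc4ccco4)ccnc3c2)c1`, whose value in this assay is 317 10^-6 cm/s. Within the data shown here, the only measured step, no change at the digits printed from compound 1 to compound 2 (within the scatter), changed the read-out not at all beyond the scatter, although it swapped a group far from the diaryl ether. Among the measured compounds shown here, compound 3 `COc1ccccc1Oc1ccc2c(NCCCNCc3cccc(OC)c3O)ccnc2c1` differs from compound 2 by 2-methoxyphenyl in place of 3-methoxyphenyl on an oxygen on an aromatic ring, the same atoms joined differently, and no measured step touches that position. No step beyond the scatter is therefore expected, so compound 3 is estimated at 317 10^-6 cm/s, within 200 10^-6 cm/s to 500 10^-6 cm/s, a step of no change at the digits printed from compound 2 to compound 3 (within the scatter).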

Compound 3, apparent permeability: 317 10^-6 cm/s
For compound 3 middle estimate and measured number coincide at the digits printed; measured number inside the range.
By their numbers in this assay, from the lowest: compounds 1, 2 and 3 (each within the scatter of the next).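

In this assay, 2-methoxyphenyl in place of 3-methoxyphenyl on an oxygen on an aromatic ring gave no change at the digits printed from compound 2 to compound 3 (within the scatter). Among these compounds, compound 1 and compound 2 differ in another place, so this step is the first reading at this position, and it shows that this exchange of one methoxyphenyl for the other leaves the read-out within the scatter. Nothing available here accounts for this result.

Still open, from the compounds shown here alone, is whether a carboxylic acid or an amine in place of the methoxy group would leave the read-out equally unmoved. A longer chain between the core and the amine also remains untested in the compounds shown here.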